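The source may hold more compounds than are shown below. What is called first, only, known or untested is meant among the compounds shown, and "the series" means these compounds.

Two members of the series are known in an ADME assay on Huh-7 cells (Homo sapiens) for cytotoxicity, read by XTT assay, with a stated time of 3 days, tested at 200 uM; on this read-out lower numbers stand for a stronger effect and higher numbers for a weaker effect at the one concentration tested: compound 1 `COc1ccc(-n2nc(-c3ccc(F)cc3)cc2-c2ccc3cc(F)ccc3n2)cc1` gives 52.6%, and compound 2 `NS(=O)(=O)c1ccc(-n2nc(-c3ccccc3)cc2-c2ccc3cc(F)ccc3n2)cc1` gives 83.6%. Compound 2 stands highest of these two numbers, and its gap to compound 1 lies beyond the scatter; the two differ in more than one place, so no single change can be tied to that gap. Compound 3 `NS(=O)(=O)c1ccc(-n2nc(-c3ccc(F)cc3)cc2-c2ccc3cc(F)ccc3n2)cc1` differs from compound 2 in one place: fluoro in place of hydrogen on an aromatic carbon. For the measured compounds named here, no step for this change alone is known; a modest step is expected, downward if anything, plausibly within the scatter. Compound 3 is estimated at 77%, with a range from 55% to 95%. The expected step is a number 6.6 percentage points lower from compound 2 to compound 3 (within the scatter).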

Compound 3, a percentage reported as activity, at one concentration (the size of the read-out at that concentration, not a potency): 43%
Compound 3: middle estimate off by 34 percentage points, on the high side, outside the stated range (below it).
By their numbers in this assay, from the lowest: compounds 3 and 1 (each within the scatter of the next); then compound 2.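

For the compounds shown here, on the phenyl ring, at the place para to a large group, the change from phenyl to 4-fluorophenyl counts for much in this assay: fluoro in place of hydrogen gives a number 40.6 percentage points lower from compound 2 to compound 3 (beyond the scatter) and is the first single change read. With the 4-fluorophenyl held, sulfamoyl in place of methoxy gives a number 9.6 percentage points lower from compound 1 to compound 3 (within the scatter) and so separates the two groups only within the scatter. No data at hand bear on the cause of either step.

From the compounds shown here alone, whether chloro, methyl or an amine at the same place gives a step of like size stays open. So does whether the fluoro step holds with methoxy in place of sulfamoyl.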